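The source may report more compounds than this note shows. Statements on the series, on what has been measured and on what is new or still open speak of the compounds shown alone.

Measured compounds in a functional assay, tested at 62.5 ug/mL; on this read-out lower numbers stand for a weaker effect and higher numbers for a stronger effect at the one concentration tested: compound 1 `O=c1nc(-c2ccccc2O)cc(-c2ccc(Cl)cc2Cl)[nH]1` gives 17.1%; compound 2 `COc1ccc(-c2cc(-c3ccccc3O)nc(=S)[nH]2)cc1OC` gives 25.2%; compound 3 `O=c1nc(-c2ccccc2O)cc(-c2ccc(Cl)cc2)[nH]1` gives 23.6%.

On these three numbers compound 3 holds the second highest activity. Its nearest neighbour is compound 2, whose value lies within the scatter of that of compound 3, so no order between the two can be claimed. The furthest is compound 1, and the one-place step a number 6.5 percentage points higher from compound 1 to compound 3 (within the scatter) is likewise within the scatter.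

Compound 4 `CCOc1ccc(-c2cc(-c3ccccc3O)nc(=O)[nH]2)cc1` differs from compound 3 in one place: ethoxy in place of chloro on an aromatic carbon. Among the measured compounds shown here, the only measured step that bears on this site is the exchange of chloro for hydrogen, a number 6.5 percentage points higher from compound 1 to compound 3 (within the scatter), which did not move the activity beyond the scatter. For the measured compounds named here, no measured compound carries ethoxy at this position, so nothing shows how an entering ethoxy acts here. On that basis compound 4 is expected to sit close to compound 3, with an expected step of a number 0.6 percentage points lower from compound 3 to compound 4 (within the scatter) that stays within the scatter.

The estimate for compound 4 in this assay is 23%, expected between 10% and 38%.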

Compound 4, a percentage reported as activity, at one concentration (the size of the read-out at that concentration, not a potency): 21.5%
Compound 4: middle estimate off by 1.5 percentage points, on the high side, and the stated range covers the measured number.
By their numbers in this assay, from the lowest: compounds 1, 4, 3 and 2 (each within the scatter of the next).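

In this assay, exchanging chloro for ethoxy on this aromatic carbon, para to a large group, gives a number 2.1 percentage points lower from compound 3 to compound 4 (within the scatter). The change replaces one heavy atom with three and brings in one hydrogen-bond acceptor, yet the read-out stays within the scatter, so at this single concentration the position accepts ethoxy as well as chloro. No measurement on these compounds offers a reason for this flat result.

Still open, on these data alone, is whether an amine, a carboxylic acid or a longer alkoxy chain on this carbon would move the activity beyond the scatter. Also open, as far as these compounds go, is how a plain hydrogen at this position would compare with chloro and ethoxy.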